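Sulfonamide aryl swap: 2,5-dimethylphenyl to 4-fluorophenyl

This account rests on a few compounds, and the source may have more. Where it says the series, first, only, none or still open, it means among the compounds named here.

Three compounds share one core. Compound 1 `O=C1NCCN1c1ccc(S(=O)(=O)Nc2ccc(I)cc2)cc1` gives 650 nM in a functional assay on HT-29 cells (Homo sapiens) for antiproliferative activity, read by sulforhodamine B assay, with a stated time of 48 h; a higher number here means a weaker inhibitor, a lower number a stronger inhibitor. Compound 2 `Cc1ccc(NS(=O)(=O)c2ccc(N3CCNC3=O)cc2)c(C)c1` gives 180 nM, and compound 3 `Cc1ccc(C)c(NS(=O)(=O)c2ccc(N3CCNC3=O)cc2)c1` gives 46 nM, the lowest of the three numbers; the steps between them are a 3.6-fold lower number from compound 1 to compound 2 (0.56 log units; beyond the scatter), a 3.9-fold lower number from compound 2 to compound 3 (0.59 log units; beyond the scatter) and a 14-fold lower number from compound 1 to compound 3 (1.15 log units; beyond the scatter). Compound 4 `O=C1NCCN1c1ccc(S(=O)(=O)Nc2ccc(F)cc2)cc1` differs from compound 3 by 4-fluorophenyl in place of 2,5-dimethylphenyl on a sulfonamide nitrogen. Among the measured compounds shown here, the step that bears on this is a 14-fold lower number from compound 1 to compound 3 (1.15 log units; beyond the scatter), which joins a 4-iodophenyl to the 2,5-dimethylphenyl; compound 4 carries a 4-fluorophenyl in that place, so a large step upward in this assay is expected, though no measured step compares a 4-fluorophenyl with a 4-iodophenyl there. The estimate for compound 4 is 600 nM (200 nM to 2000 nM). The expected step is a 13-fold higher number from compound 3 to compound 4 (1.12 log units; beyond the scatter).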

Compound 4, half-maximal inhibitory concentration: 370 nM
Compound 4: the middle estimate sits 1.6-fold (0.21 log units) above what was measured; the measured number falls inside the stated range.
By their numbers in this assay, from the lowest: compound 3; then compound 2; then compounds 4 and 1 (each within the scatter of the next).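

On the sulfonamide nitrogen, exchanging iodo for fluoro on the aromatic carbon does not separate the two halogen-bearing compounds in this assay (a 1.8-fold lower number from compound 1 to compound 4 (0.24 log units; within the scatter)). Both dimethylphenyl groups give lower numbers than the 4-fluorophenyl (an 8.0-fold higher number from compound 3 to compound 4 (0.91 log units; beyond the scatter); a 2.1-fold higher number from compound 2 to compound 4 (0.31 log units; beyond the scatter)), the 2,4-dimethylphenyl gap being only slightly beyond the scatter. No available evidence bears on what lies behind these differences.

Open, on these data alone, is how a phenyl carrying a single methyl, a methoxy or an amine on that nitrogen would compare, and whether the numbers of compound 3 require both methyl groups.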